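From 4-methylpiperazin-1-yl to dipropylamino: estimating toxicity

The compounds below may be only part of what the source reports. "The series", "measured", "known", "first", "only" and "open" are said of these compounds alone.

Measured in an ADME assay on NIH3T3 cells (Mus musculus) for cytotoxicity; on this read-out lower numbers stand for higher toxicity in this test and higher numbers for lower toxicity in this test:
- compound 1 `CN(C)CC#Cc1cc2ncnc(Nc3ccc(OCc4cccc(F)c4)c(Cl)c3)c2s1`: > 50 uM, a limit of the assay and not a number
- compound 2 `Fc1cccc(COc2ccc(Nc3ncnc4cc(C#CCN5CCCC5)sc34)cc2Cl)c1`: 6.4 uM
- compound 3 `CN1CCN(CC#Cc2cc3c(Nc4ccc(OCc5cccc(F)c5)c(Cl)c4)ncnc3s2)CC1`: 6.7 uM

Compound 3 stands level with compound 2, their values lying within the scatter of each other.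

Compound 4 `CCCN(CC#Cc1cc2c(Nc3ccc(OCc4cccc(F)c4)c(Cl)c3)ncnc2s1)CCC` carries dipropylamino in place of 4-methylpiperazin-1-yl on a saturated chain carbon bound to a triple-bonded carbon. Within the data shown here, one measured step bears on this, pyrrolidin-1-yl in place of dimethylamino: an at least 7.8-fold lower number from compound 1 to compound 2 (0.89 log units; beyond the scatter). That step went from an open chain to a ring, and this change goes the other way, so a move toward higher numbers in this assay is expected. However, dipropylamino is not dimethylamino, and the core of compound 3 differs from that of compound 1, so the expected move is small. The expected step is a 1.5-fold higher number from compound 3 to compound 4 (0.17 log units; within the scatter), hardly beyond the scatter. For compound 4 the estimate is 10 uM, with an expected range from 3.5 uM to 35 uM.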

Compound 4, half-maximal toxic concentration: 2.2 uM
For compound 4 the middle estimate is 4.5-fold (0.66 log units) above the measured one; measured number below the stated range.
By their numbers in this assay, from the lowest: compound 4; then compounds 2 and 3 (each within the scatter of the next). At a limit, above all of these: compound 1.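

In this assay, putting dipropylamino in place of 4-methylpiperazin-1-yl gives a 3.0-fold lower number from compound 3 to compound 4 (0.48 log units; beyond the scatter). Here the open-chain amine has the lower number, whereas on the core of compound 1 the ring gave the lower number, so ring versus open chain alone sets no single direction in these compounds. Nothing measured here explains this change.

The compounds shown leave open where diethylamino, with its shorter chains, or morpholin-4-yl would fall on the core of compound 3. They also leave open how dimethylamino would read on that core.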